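Swapping a biphenyl arm for a pentyl chain: toxicity outlook

This account rests on a few compounds, and the source may have more. Where it says the series, first, only, none or still open, it means among the compounds named here.

Compound 1 `Cc1ccc(-c2c3c(nc(C)c2C(OC(C)(C)C)C(=O)O)CCN(c2cccc(-c4ccccc4)c2)C3)cc1` belongs to a small set of acids built on a shared bicyclic core, each carrying a different group on the ring amine nitrogen. In an ADME assay on MT2 cells (Homo sapiens) for cytotoxicity, read by XTT assay, with a stated time of 4 days (on this read-out higher numbers stand for lower toxicity in this test and lower numbers for higher toxicity in this test), compound 1 gives > 40000 nM, which is a limit of the test rather than a measured number. Compound 2 `Cc1ccc(-c2c3c(nc(C)c2[C@H](OC(C)(C)C)C(=O)O)CCN(CCCc2ccccc2)C3)cc1` carries a phenylpropyl arm on the same nitrogen; in this assay compound 2 gives > 40000 nM, again a limit. Compound 3 `Cc1nc2c(c(-c3cc(F)c4c(c3C)CCCO4)c1[C@H](OC(C)(C)C)C(=O)O)CN(CC1CC1c1ccccc1)CC2`, with a phenylcyclopropylmethyl arm, also reaches only a limit, giving > 40000 nM in this assay. All three values therefore sit at the same boundary, as the limit of > 40000 nM in this assay, at which 3 of the 3 values shown sit, states, and none of the structural variation at this nitrogen has yet produced a toxicity readable within the tested window.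

Compound 4 `CCCCCN1CCc2nc(C)c(C(OC(C)(C)C)C(=O)O)c(-c3ccc(C)cc3)c2C1` changes the arm once more: pentyl in place of 3-phenylphenyl on an amine nitrogen in a ring. Within the data shown here, no measured step between two compounds is available to say how much the group on this nitrogen matters. Since compound 1, compound 2 and compound 3 all stop at the limit, compound 4 is expected to do the same, so the step that the limit leaves unreadable from compound 1 to compound 4 is expected to be none beyond the scatter. On that basis compound 4 is estimated at 60000 nM, with a range from 30000 nM to 200000 nM, most likely reported again only as a limit.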

Compound 4, half-maximal cytotoxic concentration: > 40000 nM
Compound 4 was reported as a limit (the forecaster's own chance of this, stated with the estimate: 85%); the middle value lies beyond the limit too.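

In this assay compound 4 gives > 40000 nM, which is a limit of the test and not a number. Among these compounds, compound 1 also stops at a limit, so no step between compound 1 and compound 4 can be read. The compounds shown leave open whether any group on this ring nitrogen would give a readable toxicity value: the limit of > 40000 nM in this assay, at which 4 of the 4 values shown sit.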